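A few compounds are considered here, and "the series" means these few. Any claim that something is new, unique, unknown or untested is made for them only; others in the source may bear on it.

Measured in a functional assay, read by spectrophotometry, with a stated time of 5 min; on this read-out lower numbers stand for stronger inhibition and higher numbers for weaker inhibition:
- compound 1 `Nc1ccccc1/N=C\c1cc(=O)oc2cc(OCc3ccccc3)cc(OCc3ccccc3)c12`: 258000 nM
- compound 2 `N/N=C\c1cc(=O)oc2cc(OCc3ccccc3)cc(OCc3ccccc3)c12`: 36500 nM

Compound 2 holds the lower of the two numbers. Compound 3 `O=c1cc(/C=N\Nc2ccc([N+](=O)[O-])cc2)c2c(OCc3ccccc3)cc(OCc3ccccc3)cc2o1` differs from it by 4-nitrophenyl in place of hydrogen on an amine nitrogen. Within the data shown here, the one measured step that bears on this is a 7.1-fold lower number from compound 1 to compound 2 (0.85 log units; beyond the scatter). It is an imperfect guide, as it concerns amino in place of 2-aminophenyl on a double-bonded nitrogen. Read in reverse, it points to a modest rise in this assay, smaller than that step. The expected change is a 2.5-fold higher number from compound 2 to compound 3 (0.39 log units; beyond the scatter). For compound 3 the estimate is 90000 nM, with an expected range from 15000 nM to 400000 nM.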

Compound 3, half-maximal inhibitory concentration: 419000 nM
Beside the measured number, compound 3's estimate is 4.7-fold (0.67 log units) below it; the whole stated range lies below it.
By their numbers in this assay, from the lowest: compound 2; then compounds 1 and 3 (each within the scatter of the next).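

In this assay, among these compounds, 4-nitrophenyl on the amine nitrogen is far from neutral, giving an 11-fold higher number from compound 2 to compound 3 (1.06 log units; beyond the scatter) and leaving compound 2 with the lowest number so far. The two compounds carrying an aromatic ring at this end of the molecule cannot be told apart, with a 1.6-fold higher number from compound 1 to compound 3 (0.21 log units; within the scatter) despite their different linkage and ring substituent. Nothing available explains these results.

Going by these compounds, it remains open whether a methyl or an unsubstituted phenyl on that amine nitrogen would stay near compound 2 or near compound 3. Whether an acetyl group there would differ from both is also unknown.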